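Aryl urea variation on a fluorophenoxy-cyclohexyl core

The source may hold more compounds than are shown below. What is called first, only, known or untested is meant among the compounds shown, and "the series" means these compounds.

Measured so far in a functional assay on CRL2813 cells (Homo sapiens) for cytotoxicity, read by sulforhodamine B assay, with a stated time of 5 days; on this read-out lower numbers stand for stronger inhibition and higher numbers for weaker inhibition:
compound 1 `O=C(Nc1ccc(I)cc1)N[C@H]1CC[C@H](Oc2ccc(F)cc2)CC1` gives 10200 nM
compound 2 `O=C(Nc1ccc(F)cc1)N[C@H]1CC[C@H](Oc2ccc(F)cc2)CC1` gives 20000 nM
compound 3 `CSc1ccccc1NC(=O)N[C@H]1CC[C@H](Oc2ccc(F)cc2)CC1` gives > 20000 nM

The value of compound 3 is a limit of this assay, not a number. Among the three measured compounds, compound 3 therefore sits at the weak end that the assay reports, alongside the one entry that reaches (the limit of > 20000 nM in this assay, at which 1 of the 3 values shown sits).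

The next compound, compound 4 `O=C(Nc1ccc([N+](=O)[O-])cc1)N[C@H]1CC[C@H](Oc2ccc(F)cc2)CC1`, differs from compound 3 only on the urea side: 4-nitrophenyl in place of 2-(methylsulfanyl)phenyl on an amide-type nitrogen. The change keeps a phenyl ring on the amide-type nitrogen and returns to a single substituent in the 4-position, as in compound 1 and compound 2.

Among the measured compounds shown here, two measured steps bear on this. The aryl swap an at least 1.9-fold higher number from compound 1 to compound 3 (0.29 log units; that floor lies within the scatter) and the aryl swap a number no lower from compound 2 to compound 3 (the limit leaves the size open) both ran from a 4-substituted phenyl toward the methylsulfanyl compound, and neither moved clearly beyond the scatter. Within the 4-substituted pair, a 2.0-fold higher number from compound 1 to compound 2 (0.29 log units; within the scatter) is also within the scatter. Going back to a 4-substituted phenyl is thus expected to give no step beyond the scatter, or at most a modest move toward lower numbers, as an at least 1.3-fold lower number from compound 3 to compound 4 (0.12 log units; that floor lies within the scatter).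

Compound 4 is therefore estimated at 15000 nM, in the range 5000 nM to 40000 nM, with a real chance that this assay again reports only a limit.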

Compound 4, half-maximal inhibitory concentration: 2300 nM
Beside the measured number, compound 4's estimate is 6.5-fold (0.81 log units) above it; measured number outside the range, below it.
By their numbers in this assay, from the lowest: compound 4; then compounds 1 and 2 (each within the scatter of the next).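

In this assay, among the compounds shown here, replacing the halogen on the aromatic carbon with nitro is the first change to move the number beyond the scatter, giving an 8.7-fold lower number from compound 2 to compound 4 (0.94 log units; beyond the scatter) and also a 4.4-fold lower number from compound 1 to compound 4 (0.65 log units; beyond the scatter) while the exchange of iodo for fluoro stayed within it. The wider aryl exchange on the amide-type nitrogen now also reads beyond the scatter, with an at least 8.6-fold lower number from compound 3 to compound 4 (0.93 log units; beyond the scatter) where the earlier aryl swaps showed no move past it. Compound 3 holds a limit of the assay and not a number, so that last step gives only a floor: the limit of > 20000 nM in this assay, at which 1 of the 4 values shown sits.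

With only nitro, iodo and fluoro as single substituents on this phenyl, the series does not tell whether the lower number is particular to nitro or would recur with a nitrile, a methyl ester or an amine on the same carbon, and it offers no cause for the step. Also open, from the compounds shown here alone, is whether the step carries over to a compound with methoxy in place of fluoro on the phenoxy side of the shared core.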